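Notes on compound 4 against compound 2

The source may report more compounds than this note shows. Statements on the series, on what has been measured and on what is new or still open speak of the compounds shown alone.

Measured in an ADME assay on L1210/0 cells (Mus musculus) for cytotoxicity, with a stated time of 48 h; on this read-out higher numbers stand for weaker inhibition and lower numbers for stronger inhibition:
- compound 1 `CO[C@@H]1OC[C@@H](OC(C)=O)[C@@H](OC(C)=O)[C@]1(F)n1ccc(=O)[nH]c1=O`: 55000 nM
- compound 2 `O=c1[nH]c(=O)n([C@H]2C[C@H](O)[C@@H](CO)O2)cc1/C=C/I`: 63900 nM
- compound 3 `CC(=O)OC(C)Cn1cnc2c(=S)[nH]c(N)nc21`: 128000 nM

Compound 2 holds the middle number of the three. It lies within the usual scatter of both neighbouring values, so the set shows no separation around it. Going by the values given here, none of the three differs from another in only one place, so no measured step is available for this series.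

The next compound is compound 4 `O=C(CI)NCc1cn([C@H]2C[C@H](O)[C@@H](CO)O2)c(=O)[nH]c1=O`, still to be measured in this assay. It keeps the core of compound 2 and changes one substituent, with (((iodomethyl)carbonyl)amino)methyl in place of 2-iodoethenyl on an aromatic carbon.

Among the compounds with values here, no measured compound carries the entering group, so the expectation is a judgement with little support from the data. All three measured values indicate weak inhibition, and compound 4 is expected to stay in the same broad region. A moderate shift toward stronger inhibition, somewhat beyond the scatter, seems more likely than no change. The expected change is a 3.2-fold lower number from compound 2 to compound 4 (0.50 log units; beyond the scatter), and this estimate is uncertain. For compound 4 the estimated value is 20000 nM, with an expected range of 4000 nM to 100000 nM.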

Compound 4, half-maximal inhibitory concentration: 107000 nM
Beside the measured number, compound 4's estimate is 5.4-fold (0.73 log units) below it, outside the stated range (above it).
By their numbers in this assay, from the lowest: compounds 1, 2, 4 and 3 (each within the scatter of the next, the first and the last beyond it).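

In this assay, going by these compounds alone, the first readable step is a 1.7-fold higher number from compound 2 to compound 4 (0.22 log units; within the scatter), and it stays within the scatter. At this aromatic carbon, two atoms from the ring nitrogen, (((iodomethyl)carbonyl)amino)methyl can therefore take the place of 2-iodoethenyl with no resolved change in the number, even though the entering group is larger, at 6 heavy atoms against 3, and adds a hydrogen-bond donor and a hydrogen-bond acceptor. Nothing available bears on why the number holds across this change.

Open, as far as these compounds go, is whether any group at this carbon separates from compound 2 beyond the scatter, for example a plain aminomethyl or a carboxylic acid, or a longer chain carrying the same amide. Also open, from the compounds shown here alone, is what the iodine contributes in either group: a chloromethyl or a plain methyl on the amide carbonyl of compound 4 would test that atom apart from the amide link.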